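A Halogenated Phenyl Swap on a Shared Core

The compounds below may be only part of what the source reports. "The series", "measured", "known", "first", "only" and "open" are said of these compounds alone.

Compound 1 `C=CCn1c(=O)/c(=C\c2ccc(F)c(Br)c2)[nH]c(=O)/c1=C\c1ccccc1OC`: "not active" (no number reported)
Compound 2 `C=CCn1c(=O)/c(=C\c2cccc(Br)c2)[nH]c(=O)/c1=C\c1ccccc1OC`: 5400 nM
Compound 3 `C=CCn1c(=O)/c(=C\c2ccccc2Cl)[nH]c(=O)/c1=C\c1ccccc1OC`: 5300 nM

These three compounds share one core and differ only in the halogenated phenyl attached to it. In a functional assay on A549 cells (Homo sapiens) for cytotoxicity, read by CCK-8 assay, with a stated time of 72 h (a lower number here means a stronger inhibitor, a higher number a weaker inhibitor), compound 2 gives 5400 nM, and compound 3 gives 5300 nM; the two numbers differ by a 1.0-fold lower number from compound 2 to compound 3 (0.01 log units; within the scatter), so they cannot be told apart. In this assay compound 1 gives "not active" (no number reported), with no number attached. Compound 3 therefore sits together with compound 2, while compound 1 stands apart without a value.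

Compound 4 `C=CCn1c(=O)/c(=C\c2cc(Br)ccc2F)[nH]c(=O)/c1=C\c1ccccc1OC` has not yet been measured. It differs from compound 3 in one place: 5-bromo-2-fluorophenyl in place of 2-chlorophenyl on a double-bonded chain carbon bound to an aromatic carbon. Among the measured compounds shown here, the only measured step that bears on this change is a 1.0-fold lower number from compound 2 to compound 3 (0.01 log units; within the scatter), which shows that exchanging one halogenated phenyl for another left the number within the scatter. Compound 1, whose phenyl also carries a bromine and a fluorine, gave no number, which raises the chance that compound 4 also falls outside the measurable range. On balance, compound 4 is expected to show a step of a 1.5-fold higher number from compound 3 to compound 4 (0.18 log units; within the scatter), a somewhat weaker result than compound 3. The estimate for compound 4 is 8000 nM, with a range from 3000 nM to 30000 nM.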

Compound 4, half-maximal inhibitory concentration: "not active" (no number reported)
For compound 4 the study gives words and no number, and the estimate cannot be compared.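

In this assay compound 4 gives "not active" (no number reported), so no step can be read from compound 3 to compound 4. No measurement shown here offers an explanation for this result. The compounds shown leave open whether carrying both bromine and fluorine on the phenyl is what links compound 1 and compound 4, which both lack a number.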